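From hydroxy to carboxy on a sulfanyl side chain

The compounds below may be only part of what the source reports. "The series", "measured", "known", "first", "only" and "open" are said of these compounds alone.

In a functional assay on the whole organism with Mus musculus as the target (a higher number here means that more compound is needed for the effect, a lower number that less compound is needed), compound 1 `Cc1c(C)c2c(c(C)c1N)CC(C)(C)O2` gives 7.8 mg/kg, and compound 2 `Cc1c(C)c2c(c(C)c1N)CC(C)(CSc1nccn1C)O2` gives 37.1 mg/kg. Compound 3 `Cc1c(C)c2c(c(C)c1N)CC(C)(CSCCO)O2` gives > 50 mg/kg, which is a limit only. Compound 4 `Cc1c(C)c2c(c(C)c1N)CC(C)(CSCCC(=O)O)O2` differs from it by carboxy in place of hydroxy on a saturated chain carbon, two bonds along the chain from a sulfur, with carboxy in place of hydroxy on a saturated chain carbon, two bonds along the chain from a sulfur.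

Among the compounds with values here, no measured step makes this exchange. The nearest evidence is a 4.8-fold higher number from compound 1 to compound 2 (0.68 log units; beyond the scatter) and an at least 6.4-fold higher number from compound 1 to compound 3 (0.80 log units; beyond the scatter), both modest or larger and both towards higher numbers, alongside an at least 1.3-fold higher number from compound 2 to compound 3 (0.12 log units; that floor lies within the scatter). The number is therefore expected to remain high, and the expected step, a step that the limit leaves unreadable from compound 3 to compound 4, is none beyond the scatter. For compound 4 the estimate is 60 mg/kg, with an expected range of 30 mg/kg to 120 mg/kg.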

Compound 4, dose for 50% inhibition: 43 mg/kg
For compound 4 the middle estimate is 1.4-fold (0.14 log units) above the measured one; the range from low to high includes it.
By their numbers in this assay, from the lowest: compound 1; then compounds 2 and 4 (each within the scatter of the next). At a limit, above all of these: compound 3.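

In this assay carboxy in place of hydroxy gives an at least 1.1-fold lower number from compound 3 to compound 4 (0.06 log units; that floor lies within the scatter), and this step stays open on one side, since compound 3 is held only by a limit: the limit of > 50 mg/kg in this assay, at which 1 of the 4 values shown sits.

The 2-carboxyethyl group on the sulfur gives a 1.2-fold higher number from compound 2 to compound 4 (0.06 log units; within the scatter), so these two sulfur substituents cannot be told apart in this assay. In place of hydrogen, the (2-carboxyethyl)sulfanyl group gives a 5.5-fold higher number from compound 1 to compound 4 (0.74 log units; beyond the scatter), the same direction as the other two sulfanyl groups.

On these data alone, whether an amine at the end of this chain, or a longer chain ending in a carboxylic acid, would bring the number back towards that of compound 1 stays open.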